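The source may hold more compounds than are shown below. What is called first, only, known or untested is meant among the compounds shown, and "the series" means these compounds.

Measured in an assay on RBL-1 cells for inhibition of Polyunsaturated fatty acid 5-lipoxygenase (Rattus norvegicus); a lower number here means a stronger inhibitor, a higher number a weaker inhibitor: compound 1 `CCCCOc1ccc(C(C)N(O)C=O)cc1` gives 1900 nM; compound 2 `CC(c1ccc(OCc2ccccc2)cc1)N(O)C(=O)c1ccccc1` gives 690 nM.

Of these two, compound 2 has the lower number, and its gap to compound 1 lies beyond the usual scatter. Compound 3 `CCCCOc1ccc(C(C)N(O)C(=O)c2ccccc2)cc1` is compound 2 with one change: propyl in place of phenyl on a saturated chain carbon bound to an oxygen on an aromatic ring. Among the compounds with values here, no pair of measured compounds differs only in this spot, so the size of this step cannot be read from the data; compound 1 and compound 2 differ in two places at once, and their values show only that compound 1 has the higher number. The expected step is a 2.2-fold higher number from compound 2 to compound 3 (0.34 log units; beyond the scatter), a modest weakening at most. Compound 3 is estimated at 1500 nM in this assay, with a range from 500 nM to 5000 nM.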

Compound 3, half-maximal inhibitory concentration: 1300 nM
For compound 3 the middle estimate is 1.2-fold (0.06 log units) above the measured one; the range from low to high includes it.
By their numbers in this assay, from the lowest: compounds 2, 3 and 1 (each within the scatter of the next, the first and the last beyond it).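

Replacing benzyloxy with butoxy gives a 1.9-fold higher number from compound 2 to compound 3 (0.28 log units; within the scatter) in this assay and so stays within the scatter, which the earlier pair could not show with two places changed at once. Putting phenyl in place of hydrogen on the carbonyl carbon can now be read alone too: it gives a 1.5-fold lower number from compound 1 to compound 3 (0.16 log units; within the scatter) and also stays within the scatter. Nothing available explains either step. Still open, on these data alone, is whether a longer chain such as hexyloxy, or an amine at the chain end, would shift the value beyond the scatter. Also open, as far as these compounds go, is how a methyl on the carbonyl carbon would compare with hydrogen and phenyl.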